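From a Benzyl Amide Back to a Small Alkyl

The compounds below may be only part of what the source reports. "The series", "measured", "known", "first", "only" and "open" are said of these compounds alone.

Compound 3 `COc1ccc(CNC(=O)c2cc(Oc3ccc(/C=C/c4ccccn4)cc3)ccn2)cc1` gives 63600 nM in a functional assay on A549 cells (Homo sapiens) for antiproliferative activity, read by CCK-8 assay, with a stated time of 48 h (on this read-out higher numbers stand for weaker inhibition and lower numbers for stronger inhibition), the highest of the three numbers shown. Compound 1 `CNC(=O)c1cc(Oc2ccc(/C=C/c3ccccn3)cc2)ccn1` gives 17400 nM and compound 2 `O=C(Nc1ccc(Cl)cc1)c1cc(Oc2ccc(/C=C/c3ccccn3)cc2)ccn1` gives 16200 nM. Compound 4 `CC(C)NC(=O)c1cc(Oc2ccc(/C=C/c3ccccn3)cc2)ccn1` differs from compound 3 by isopropyl in place of 4-methoxybenzyl on an amide-type nitrogen. The step of a 3.7-fold higher number from compound 1 to compound 3 (0.56 log units; beyond the scatter) bears most directly on this change, and a 3.9-fold higher number from compound 2 to compound 3 (0.59 log units; beyond the scatter) points the same way, whereas a 1.1-fold lower number from compound 1 to compound 2 (0.03 log units; within the scatter) shows methyl and 4-chlorophenyl giving like numbers. Since isopropyl, like methyl, carries no ring, compound 4 is expected to undo most of the rise seen in a 3.7-fold higher number from compound 1 to compound 3 (0.56 log units; beyond the scatter). Compound 4 is therefore estimated at 20000 nM, with a range of 8000 nM to 50000 nM. This estimate means an expected step of a 3.2-fold lower number from compound 3 to compound 4 (0.50 log units; beyond the scatter).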

Compound 4, half-maximal inhibitory concentration: 21400 nM
The estimate for compound 4 lay 1.1-fold (0.03 log units) below the measured number; the range from low to high includes it.
By their numbers in this assay, from the lowest: compounds 2, 1 and 4 (each within the scatter of the next); then compound 3.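

In this assay, isopropyl on the amide-type nitrogen gives a clear gain over 4-methoxybenzyl (a 3.0-fold lower number from compound 3 to compound 4 (0.47 log units; beyond the scatter)), yet it offers no gain over methyl (a 1.2-fold higher number from compound 1 to compound 4 (0.09 log units; within the scatter)) or 4-chlorophenyl (a 1.3-fold higher number from compound 2 to compound 4 (0.12 log units; within the scatter)). Among these four compounds, only compound 3 stands apart, and the ring-bearing compound 2 shows that carrying a ring does not alone set a compound apart. Nothing available explains why 4-methoxybenzyl differs. As far as these compounds go, whether unsubstituted benzyl, or a longer chain ending in an amine, would track compound 3 or compound 4 stays open.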